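Extending a prenyl side chain on a polyprenylated acylphloroglucinol core

This account rests on a few compounds, and the source may have more. Where it says the series, first, only, none or still open, it means among the compounds named here.

Of the compounds shown here, three of a shared core have been measured in a functional assay on HCT-116 cells (Homo sapiens) for inhibition; on this read-out higher numbers stand for weaker inhibition and lower numbers for stronger inhibition. Compound 1 `CC(C)=CCC/C(C)=C/C[C@]12C[C@@H](CC=C(C)C)C(C)(C)[C@](CC=C(C)C)(C(=O)C(C(=O)c3ccc(O)c(O)c3)=C1O)C2=O` gives 8.6 ug/mL there, the lowest of the two numbers reported. Compound 2 `CC(C)=CCC/C(C)=C/C[C@]12C(=O)CC(=O)[C@](CC=C(C)C)(C[C@@H](CC=C(C)C)C1(C)C)C2=O` gives 10.9 ug/mL in this assay, a gap from compound 1 that sits within the usual scatter, so no order between them is claimed. Compound 3 `CC(C)=CCC/C(C)=C/C[C@@H]1C[C@]2(CC=C(C)C)C(=O)[C@@](CC=C(C)C)(C(=O)C(C(=O)c3ccc(O)c(O)c3)=C2O)C1(C)C` yields only a limit in this assay, > 20 ug/mL, and not a number. That value stands at the limit of > 20 ug/mL in this assay, at which 1 of the 3 values shown sits.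

Compound 4 `CC(C)=CCC/C(C)=C/C[C@]12C[C@@H](CC=C(C)C)C(C)(C)[C@](C/C=C(\C)CCC=C(C)C)(C(=O)C(C(=O)c3ccc(O)c(O)c3)=C1O)C2=O` has not yet been measured. It differs from compound 1 in one place: 3-methylbut-2-en-1-yl in place of hydrogen on a saturated chain carbon bound to a double-bonded chain carbon. Among the compounds with values here, no pair of measured compounds differing in a single place is available to calibrate a step of this kind, so the expectation rests on compound 1 alone. Because compound 1 gives 8.6 ug/mL and the change adds only a hydrocarbon chain, the step of a 1.2-fold higher number from compound 1 to compound 4 (0.07 log units; within the scatter) is expected to be small, in no clear direction beyond the scatter. Compound 4 is estimated at 10 ug/mL in this assay, between 4.5 ug/mL and 20 ug/mL.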

Compound 4, half-maximal inhibitory concentration: > 20 ug/mL
Compound 4 ended at the assay's limit; the forecaster's own chance of this, stated with the estimate: 20%; at least 2.0-fold (0.30 log units) between middle value and limit.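

Swapping the 3-methylbut-2-en-1-yl chain of compound 1 for the 3,7-dimethylocta-2,6-dien-1-yl chain of compound 4 gives the first step in this set that can be read at a single place: an at least 2.3-fold higher number from compound 1 to compound 4 (0.36 log units; beyond the scatter) in this assay. It shows that this place on the shared core does not accept added hydrocarbon chain freely, as the step lies beyond the scatter even though the entering 3-methylbut-2-en-1-yl carries no hydrogen-bond donors or acceptors and no net charge. In this assay compound 4 gives > 20 ug/mL, which is a limit and not a number, and it adds to the values held at that limit: the limit of > 20 ug/mL in this assay, at which 2 of the 4 values shown sit.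

What the compounds shown leave open is whether a shorter chain such as ethyl, or a chain ending in a carboxylic acid or an amine, would behave differently at this place. They also leave open whether the same extension on another 3-methylbut-2-en-1-yl chain of the core would give a similar step.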